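This account rests on a few compounds, and the source may have more. Where it says the series, first, only, none or still open, it means among the compounds named here.

Measured compounds:
compound 1 `COc1nc2ccc(Br)cc2cc1C(c1ccccc1)n1cc(-c2ccc(Br)cc2)nn1` — 7.43%
compound 2 `CCCCCCCc1cn(C(c2ccccc2)c2cc3cc(Br)ccc3nc2OC)nn1` — 4.42%
compound 3 `CCCCc1cn(C(c2ccccc2)c2cc3cc(Br)ccc3nc2OC)nn1` — 5.54%

In an ADME assay on PC-3 cells (Homo sapiens) for cytotoxicity, read by sulforhodamine B assay, with a stated time of 48 h, tested at 10 uM (on this read-out higher numbers stand for more inhibition at the one concentration tested (going by the name of the read-out) and lower numbers for less inhibition), compound 3 sits second highest of the three numbers. Its nearest neighbour is compound 2, at a number 1.1 percentage points higher from compound 2 to compound 3 (within the scatter); its furthest is compound 1, at a number 1.9 percentage points lower from compound 1 to compound 3 (within the scatter). The third step among the measured compounds, a number 3 percentage points lower from compound 1 to compound 2 (within the scatter), is likewise within the scatter, so across the three compounds the group on the aromatic carbon of the five-membered ring has not moved the number beyond what repeated measurements would show.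

Compound 4 `CCOC(=O)c1cn(C(c2ccccc2)c2cc3cc(Br)ccc3nc2OC)nn1` is not yet measured. Its change from compound 3 is ethoxycarbonyl in place of butyl on an aromatic carbon. Within the data shown here, no measured step introduces an ethoxycarbonyl group, so none bears on this change directly; the steps that bear on it indirectly are those at the same aromatic carbon, where 4-bromophenyl, heptyl and butyl all gave numbers within the scatter of one another. On that basis the expected step from compound 3 to compound 4 in this assay is a number 0.5 percentage points higher from compound 3 to compound 4 (within the scatter), in no direction beyond the scatter. Compound 4 is therefore estimated at 6% in this assay, with an expected range from 0% to 15%.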

Compound 4, a percentage reported as inhibition, at one concentration (the size of the read-out at that concentration, not a potency): 16.1%
For compound 4 the middle estimate is 10.1 percentage points below the measured one, and the stated range ends below it.
By their numbers in this assay, from the lowest: compounds 2, 3, 1 and 4 (each within the scatter of the next, the first and the last beyond it).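

In this assay, among these compounds, ethoxycarbonyl is the first group at this aromatic carbon of the five-membered ring to give a step beyond the scatter, both in place of butyl (a number 10.6 percentage points higher from compound 3 to compound 4 (beyond the scatter)) and in place of heptyl (a number 11.7 percentage points higher from compound 2 to compound 4 (beyond the scatter)). The change therefore separates this group from the two alkyl chains, whereas compound 1 goes against any wider reading, as the step from 4-bromophenyl stays within the scatter (a number 8.7 percentage points higher from compound 1 to compound 4 (within the scatter)), so ethoxycarbonyl cannot be set apart from every group shown at this carbon. Nothing at hand gives a measured property that would account for these steps.

The compounds shown leave open whether the higher number belongs to the ethoxycarbonyl group as a whole or to a part of it, a question that a carboxylic acid, a primary amide or a methoxycarbonyl group at the same carbon would address. They also leave open whether the step would hold at other concentrations, as every number here comes from a single concentration and none is a potency.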